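Methoxy replacing methylamino on the shared core

This account rests on a few compounds, and the source may have more. Where it says the series, first, only, none or still open, it means among the compounds named here.

Compound 1 `COc1ncnc2c1c(-c1ccoc1)cn2[C@@H]1O[C@H](CO)[C@@H](O)[C@H]1O` gives 130 nM in a functional assay on HCT-116 cells (Homo sapiens), read by MTT assay, with a stated time of 72 h; a higher number here means a weaker inhibitor, a lower number a stronger inhibitor.
Compound 2 `C#Cc1cn([C@@H]2O[C@H](CO)[C@@H](O)[C@H]2O)c2ncnc(N(C)C)c12` gives 290 nM in this assay.
Compound 3 `C#Cc1cn([C@@H]2O[C@H](CO)[C@@H](O)[C@H]2O)c2ncnc(NC)c12` gives only a limit in this assay: > 20000 nM.

Compound 3 therefore has no number of its own; its result sits at the limit of > 20000 nM in this assay, at which 1 of the 3 values shown sits. Going by the values given here, the only step that reaches it, an at least 68-fold higher number from compound 2 to compound 3 (1.83 log units; beyond the scatter), is large. The next compound, compound 4 `C#Cc1cn([C@@H]2O[C@H](CO)[C@@H](O)[C@H]2O)c2ncnc(OC)c12`, differs from compound 3 by methoxy in place of methylamino on an aromatic carbon. Among the compounds with values here, no measured step reports exactly this change. Compound 1, which also carries a methoxy group on the shared core, gives 130 nM, and compound 2 gives 290 nM, so the methoxy compound 4 is expected to fall back to the level of those two. Compound 4 is estimated at 200 nM, within 50 nM to 1500 nM, an expected step of an at least 100-fold lower number from compound 3 to compound 4 (2.00 log units; beyond the scatter).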

Compound 4, half-maximal inhibitory concentration: 5140 nM
For compound 4 the middle estimate is 26-fold (1.41 log units) below the measured one; the whole stated range lies below it.
By their numbers in this assay, from the lowest: compound 1; then compound 2; then compound 4. At a limit, above all of these: compound 3.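

In this assay, methoxy in place of methylamino gives an at least 3.8-fold lower number from compound 3 to compound 4 (0.59 log units; beyond the scatter), so this change on the aromatic carbon recovers some activity. Methoxy still falls well short of dimethylamino, with an 18-fold higher number from compound 2 to compound 4 (1.25 log units; beyond the scatter). With methoxy held constant, ethynyl in place of furan-3-yl gives a 40-fold higher number from compound 1 to compound 4 (1.60 log units; beyond the scatter), so the result here also depends on the other group on the shared core.

On these data alone, compound 3 has only a limit, so the true size of its step stays unknown: the limit of > 20000 nM in this assay, at which 1 of the 4 values shown sits. How a free amino group or ethoxy on this carbon would behave remains open.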